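A few compounds are considered here, and "the series" means these few. Any claim that something is new, unique, unknown or untested is made for them only; others in the source may bear on it.

Working notes on the series. All three compounds share the same core and differ at the sulfur link and on the amide-type nitrogen. Compound 1 `COc1cc2nc(SCC(=O)Nc3cccc(S(N)(=O)=O)c3)nc(Nc3c(Cl)cc(/C=C/C#N)cc3Cl)c2cc1OC` has the unoxidised sulfur link. In an ADME assay on MT4 cells (Homo sapiens) for cytotoxicity, read by MTT assay, with a stated time of 5 days (a higher number here means that more compound is tolerated, a lower number that less compound is tolerated), compound 1 gives only a limit of the assay, > 194000 nM, and no number. Compound 2 `COc1cc2nc([S+]([O-])CC(=O)Nc3ccc(Cl)cc3)nc(Nc3c(Cl)cc(/C=C/C#N)cc3Cl)c2cc1OC` has the oxidised sulfur link and a 4-chlorophenyl on the amide-type nitrogen. In this assay, for the measured compounds named here, compound 2 gives 14400 nM, the only number in the set. For compound 1 the value is a limit (the limit of > 194000 nM in this assay, at which 1 of the 2 values shown sits). Compound 2 therefore cannot be ranked against compound 1 beyond that. Compound 3 `COc1cc2nc([S+]([O-])CC(=O)Nc3cc([N+](=O)[O-])ccc3F)nc(Nc3c(Cl)cc(/C=C/C#N)cc3Cl)c2cc1OC` keeps the oxidised sulfur link, and the change from compound 2 is 2-fluoro-5-nitrophenyl in place of 4-chlorophenyl on an amide-type nitrogen. Going by the values given here, no measured pair in the set differs in a single place, so the effect of such an exchange on tolerated concentration is untested here. The expected step is a 1.0-fold lower number from compound 2 to compound 3 (0.01 log units; within the scatter) in this assay, which is none beyond the usual scatter. Compound 3 is therefore estimated at 14000 nM in this assay, with a range from 5000 nM to 50000 nM.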

Compound 3, half-maximal cytotoxic concentration: > 194000 nM
Compound 3 ended at the assay's limit; the forecaster's own chance of this, stated with the estimate: 15%; middle value at least 13-fold (1.14 log units) away from the limit.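

On the oxidised sulfur link, the group on the amide-type nitrogen now has a readable effect in this assay: 2-fluoro-5-nitrophenyl in place of 4-chlorophenyl gives an at least 13-fold higher number from compound 2 to compound 3 (1.12 log units; beyond the scatter). For the compounds shown here, this is the first comparison that differs in a single place, and it shows that this position is not neutral for the tolerated concentration, since the step lies beyond the usual scatter. The value of compound 3 is a limit of the assay and not a number, so the step carries that limit with it: the limit of > 194000 nM in this assay, at which 2 of the 3 values shown sit.

Which part of the exchange carries the step stays open, as the loss of chlorine and the arrival of fluorine and the nitro group come together here, and a phenyl bearing only the nitro group or only the fluorine would separate them. Also open, going by these compounds, are how an amine or a carboxylic acid on this ring would read, and whether the same exchange holds on the unoxidised sulfur link, as compound 1 differs from compound 3 in more than one place.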